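The source may report more compounds than this note shows. Statements on the series, on what has been measured and on what is new or still open speak of the compounds shown alone.

Compound 1 `OCc1cc2cc(/C(=N\O)Nc3cccc(F)c3)ccc2o1`: 1700 nM
Compound 2 `OCc1cc2cc(/C(=N\O)Nc3cccc(Br)c3)ccc2o1`: 710 nM

In an assay on isolated protein for inhibition of Indoleamine 2,3-dioxygenase 1 (Homo sapiens), read by spectrophotometry (a higher number here means a weaker inhibitor, a lower number a stronger inhibitor), compound 2 holds the lowest of the two numbers shown, and its only neighbour is compound 1, separated by a 2.4-fold lower number from compound 1 to compound 2 (0.38 log units; beyond the scatter), a modest step tied to the halogen on the aniline ring. Compound 3 `O/N=C(/Nc1cccc(Br)c1)c1ccc2oc(-c3ccccc3)cc2c1` has not yet been measured; it differs from compound 2 by phenyl in place of hydroxymethyl on an aromatic carbon. Going by the values given here, the single measured step concerns the halogen and says nothing about this part of the shared core, so no measured step bears on the change from compound 2 to compound 3. What is expected for compound 3 in this assay therefore rests on compound 2 alone, with a wide margin: it is expected to give 800 nM, within a range from 200 nM to 3000 nM. This corresponds to an expected step of a 1.1-fold higher number from compound 2 to compound 3 (0.05 log units; within the scatter), that is, no step beyond the scatter is expected in either direction.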

Compound 3, half-maximal inhibitory concentration: 900 nM
Compound 3: middle estimate off by 1.1-fold (0.05 log units), on the low side, within the range that was stated.
By their numbers in this assay, from the lowest: compounds 2, 3 and 1 (each within the scatter of the next, the first and the last beyond it).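

At this position on the five-membered aromatic ring, next to the ring oxygen, the exchange of hydroxymethyl for phenyl gives a 1.3-fold higher number from compound 2 to compound 3 (0.10 log units; within the scatter) in this assay. Going by these compounds alone, the earlier compounds varied only the halogen, so this pair is the first sign that the position accepts a six-membered aromatic ring of carbon only in place of a group with a hydrogen-bond donor and acceptor, with no step beyond the scatter. No measurement at hand accounts for this result.

Going by these compounds, whether an amine, a carboxylic acid or a longer chain at this position would stay within the scatter of compound 2 remains open. Also open, on these data alone, is whether the halogen step, a 2.4-fold lower number from compound 1 to compound 2 (0.38 log units; beyond the scatter), would recur with phenyl in place of hydroxymethyl.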